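This account rests on a few compounds, and the source may have more. Where it says the series, first, only, none or still open, it means among the compounds named here.

Measured so far:
- compound 1 `O=C([C@@H]1CCCN(S(=O)(=O)c2ccc(S(=O)(=O)C3CCC3)cc2)C1)N1CCC(F)(F)CC1`: 12.6 nM
- compound 2 `CCN(CC)S(=O)(=O)c1ccc(S(=O)(=O)N2CCC[C@@H](C(=O)N3CCC(O)CC3)C2)cc1`: 230 nM
- compound 3 `CCN(CC)S(=O)(=O)c1ccc(S(=O)(=O)N2CCC[C@@H](C(=O)N[C@H]3CC[C@@H](OC)CC3)C2)cc1`: 590 nM

In a functional assay on MIA PaCa-2 cells (Homo sapiens) for inhibition, read by MTT assay, with a stated time of 3 days (on this read-out higher numbers stand for weaker inhibition and lower numbers for stronger inhibition), compound 2 gives the second highest of the three numbers; compound 3 is nearest, compound 1 furthest. Compound 4 `CCN(CC)S(=O)(=O)c1ccc(S(=O)(=O)N2CCC[C@@H](C(=O)N3CCC(COC)CC3)C2)cc1` differs from compound 2 in one place: methoxymethyl in place of hydroxy on a saturated ring carbon. Within the data shown here, the only measured step at the same carbonyl, a 2.6-fold higher number from compound 2 to compound 3 (0.41 log units; beyond the scatter), exchanged the whole 4-hydroxypiperidin-1-yl ring and so bears only loosely here; compound 1 differs from compound 2 in two places and gives no step. With the hydroxy leaving, a modest rise beyond the scatter is expected, a 1.5-fold higher number from compound 2 to compound 4 (0.18 log units; within the scatter), though a change within the scatter is also plausible. Compound 4 is therefore estimated at 350 nM, in the range 120 nM to 1000 nM.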

Compound 4, half-maximal inhibitory concentration: 50 nM
For compound 4 the middle estimate is 7.0-fold (0.85 log units) above the measured one; the measured number lies below the stated range.
By their numbers in this assay, from the lowest: compound 1; then compound 4; then compound 2; then compound 3.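

In this assay, the saturated ring carbon three ring bonds from the ring nitrogen accepts a larger group with no hydrogen-bond donor: methoxymethyl in place of hydroxy gives a 4.6-fold lower number from compound 2 to compound 4 (0.66 log units; beyond the scatter), in the direction of stronger inhibition. At the carbonyl, 4-(methoxymethyl)piperidin-1-yl in place of (4-methoxycyclohexyl)amino gives a 12-fold lower number from compound 3 to compound 4 (1.07 log units; beyond the scatter), so the group on this carbonyl strongly affects the read-out. No available evidence accounts for either step.

Still open, going by these compounds, is whether the step follows the ether oxygen or the added carbons. A propyl chain at this ring carbon would test the first, and a plain methoxy group the second.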